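Methoxy shift on the nitro compound of the series

A few compounds are considered here, and "the series" means these few. Any claim that something is new, unique, unknown or untested is made for them only; others in the source may bear on it.

Values in a functional assay on QG-56 cells (Homo sapiens) for antiproliferative activity (on this read-out higher numbers stand for weaker inhibition and lower numbers for stronger inhibition), so far:
- compound 1 `COc1cccc(-c2cc([N+](=O)[O-])cc3cc(C(O)(c4ccc(C#N)cc4)c4cncn4C)oc23)c1` gives 38.8 nM
- compound 2 `COc1cccc(-c2cc(C(N)=O)cc3cc(C(O)(c4ccc(C#N)cc4)c4cncn4C)oc23)c1` gives 8.2 nM
- compound 3 `COc1ccc(-c2cc([N+](=O)[O-])cc3cc(C(O)(c4ccc(C#N)cc4)c4cncn4C)oc23)cc1` is not yet measured

Compound 1 holds the higher of the two numbers. The change to compound 3 is 4-methoxyphenyl in place of 3-methoxyphenyl on an aromatic carbon. For the measured compounds named here, the only measured step (a 4.7-fold lower number from compound 1 to compound 2 (0.68 log units; beyond the scatter)) is carbamoyl in place of nitro, a change at another place, so it gives no direction here and only a rough size. The expected step (a 1.1-fold lower number from compound 1 to compound 3 (0.04 log units; within the scatter)) is therefore no larger than that one, with its direction open. Compound 3 is estimated at 35 nM (range 12 nM to 100 nM).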

Compound 3, half-maximal inhibitory concentration: 36 nM
Estimate against measurement, compound 3: 1.0-fold (0.01 log units) below, within the range that was stated.
By their numbers in this assay, from the lowest: compound 2; then compounds 3 and 1 (each within the scatter of the next).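

In this assay, 4-methoxyphenyl in place of 3-methoxyphenyl gives a 1.1-fold lower number from compound 1 to compound 3 (0.03 log units; within the scatter), so the two methoxyphenyl groups cannot be told apart on the nitro compounds. For the compounds shown here, this is the first reading at this aromatic carbon, as the earlier step concerned only carbamoyl in place of nitro at another place. No data on the origin of this result are available.

From the compounds shown here alone, whether the same holds with carbamoyl in place of nitro remains open. Also open, going by these compounds, is how an amine or a carboxylic acid in place of the methoxy group would read.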